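Swapping a Nitrobenzyl Group for a Difluorobenzyl Group

The source may hold more compounds than are shown below. What is called first, only, known or untested is meant among the compounds shown, and "the series" means these compounds.

Of the compounds shown here, three sharing one core have been tested in a functional assay on PC-3 cells (Homo sapiens) for cytotoxicity, read by MTT assay, with a stated time of 48 h; a higher number here means a weaker inhibitor, a lower number a stronger inhibitor. Compound 1 `O=C(O)CN1C(=O)/C(=C/c2nc3ccccc3n2Cc2ccc([N+](=O)[O-])cc2)SC1=S` gives 8270 nM, the second highest of the three numbers. Compound 2 `Cc1ccc(Cn2c(/C=C3\SC(=S)N(CC(=O)O)C3=O)nc3ccccc32)cc1` gives 2640 nM in this assay, and compound 3 `O=C(O)CN1C(=O)/C(=C/c2nc3ccccc3n2Cc2ccc(F)cc2F)SC1=S` gives 21700 nM. The step of a 3.1-fold lower number from compound 1 to compound 2 (0.50 log units; beyond the scatter) and the step of a 2.6-fold higher number from compound 1 to compound 3 (0.42 log units; beyond the scatter) place compound 1 between the other two, with both gaps beyond the scatter.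

Compound 4 `O=C(O)CN1C(=O)/C(=C/c2nc3ccccc3n2Cc2ccc(F)c(F)c2)SC1=S` has not yet been measured. It differs from compound 1 in one place: 3,4-difluorophenyl in place of 4-nitrophenyl on a saturated chain carbon bound to an aromatic nitrogen. The step that bears most directly on this change is a 2.6-fold higher number from compound 1 to compound 3 (0.42 log units; beyond the scatter), where a difluorophenyl group likewise replaced the nitrophenyl group on the same carbon, there as 2,4-difluorophenyl rather than 3,4-difluorophenyl. The step of an 8.2-fold higher number from compound 2 to compound 3 (0.91 log units; beyond the scatter) points the same way. A modest rise in the number is therefore expected for compound 4 in this assay, roughly a 1.9-fold higher number from compound 1 to compound 4 (0.29 log units; within the scatter). Compound 4 is estimated at 16000 nM, with a range from 6000 nM to 42000 nM.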

Compound 4, half-maximal inhibitory concentration: 5970 nM
Beside the measured number, compound 4's estimate is 2.7-fold (0.43 log units) above it; the whole stated range lies above it.
By their numbers in this assay, from the lowest: compound 2; then compounds 4 and 1 (each within the scatter of the next); then compound 3.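

The 3,4-difluorophenyl group stands level with the 4-nitrophenyl group on this carbon in this assay, with a 1.4-fold lower number from compound 1 to compound 4 (0.14 log units; within the scatter) as the step, so a difluorophenyl group here does not by itself raise the number. Which ring carbons carry the two fluorines does matter, since a 3.6-fold lower number from compound 3 to compound 4 (0.56 log units; beyond the scatter) separates two groups that differ only in that respect. The 4-methylphenyl group keeps the lowest number of the four, and a 2.3-fold higher number from compound 2 to compound 4 (0.35 log units; beyond the scatter) shows that the 3,4-difluorophenyl group does not reach it.

The compounds shown leave open how a plain phenyl group or a 4-aminophenyl group on this same carbon would compare with these four. No measurement given here explains any of these differences.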